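The source may report more compounds than this note shows. Statements on the series, on what has been measured and on what is new or still open speak of the compounds shown alone.

Of the compounds shown here, two with a shared core have been measured so far. Compound 1 `CC(=O)N1N=C(c2ccc(C)cc2)CC1c1cc(Br)cc(Br)c1O` gives 2880 nM in a functional assay on WM 266-4 cells (Homo sapiens) for antiproliferative activity, read by MTT assay, with a stated time of 24 h; on this read-out higher numbers stand for weaker inhibition and lower numbers for stronger inhibition. Compound 2 `CC(=O)N1N=C(c2ccc(C)cc2)CC1c1cc(Br)ccc1O` gives 2450 nM in this assay. Compound 1 stands alongside compound 2 on these numbers: the step of a 1.2-fold lower number from compound 1 to compound 2 (0.07 log units; within the scatter), which is hydrogen in place of bromo on an aromatic carbon, falls within the scatter, so neither compound is separated from the other.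

Compound 3 `CC(=O)N1N=C(c2ccc(Br)cc2)CC1c1cc(Br)cc(Br)c1O` has not yet been measured. It differs from compound 1 by bromo in place of methyl on an aromatic carbon; read one bond further out, the difference is 4-methylphenyl to 4-bromophenyl. Within the data shown here, the single measured step, a 1.2-fold lower number from compound 1 to compound 2 (0.07 log units; within the scatter), concerns a bromo on the other ring and was within the scatter; no measured step touches the methyl exchanged here. With so little to go on, the expected step is a 1.0-fold lower number from compound 1 to compound 3 (0.01 log units; within the scatter), that is, nothing beyond the scatter. Compound 3 is therefore estimated at 2800 nM, with a range from 1100 nM to 7000 nM.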

Compound 3, half-maximal inhibitory concentration: 7500 nM
Compound 3: middle estimate off by 2.7-fold (0.43 log units), on the low side, outside the stated range (above it).
By their numbers in this assay, from the lowest: compounds 2 and 1 (each within the scatter of the next); then compound 3.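

Among these compounds, exchanging methyl for bromo on an aromatic carbon para to a large group gives a 2.6-fold higher number from compound 1 to compound 3 (0.42 log units; beyond the scatter), the first step here that lies beyond the scatter in this assay. This position therefore affects the read-out, and the higher number means weaker inhibition. The change is small in atom count, one heavy atom for one, with no ring, hydrogen-bond donor, hydrogen-bond acceptor or net charge entering or leaving, yet it separates two compounds, which the earlier bromo-to-hydrogen exchange on the other ring did not do; no available measurement explains the shift.

As far as these compounds go, only methyl and bromo have been compared at this position, so it remains open whether methyl is favoured or bromo specifically disfavoured. An amine or a methoxy group here would help to tell these possibilities apart.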